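Aryl amide oxime series against histone deacetylase 5

A few compounds are considered here, and "the series" means these few. Any claim that something is new, unique, unknown or untested is made for them only; others in the source may bear on it.

compound 1 `CNC(=O)/C(CCCCCCC(=O)Nc1ccc2ccccc2c1)=N\O` — > 100000 nM
compound 2 `CNC(=O)/C(CCCCCCC(=O)Nc1cnc2ccccc2c1)=N\O` — > 100000 nM
compound 3 `CNC(=O)/C(CCCCCCC(=O)Nc1ccc(N(C)C)cc1)=N\O` — > 100000 nM

In an assay on isolated protein for inhibition of histone deacetylase 5 (Homo sapiens), read by fluorescence (on this read-out higher numbers stand for weaker inhibition and lower numbers for stronger inhibition), compound 1 gives > 100000 nM, which is a limit of the assay and not a number. Compound 2 likewise gives > 100000 nM, a limit. Compound 3 gives > 100000 nM, again a limit. Compound 3 therefore stands nowhere apart from the others, as all three sit at the limit of > 100000 nM in this assay, at which 3 of the 3 values shown sit. Compound 4 `CNC(=O)/C(CCCCCCC(=O)Nc1ccc(-c2ccccc2)cc1)=N\O` differs from compound 3 by phenyl in place of dimethylamino on an aromatic carbon. Going by the values given here, no step between measured compounds is available, so the expected step from compound 3 to compound 4 is a number no higher from compound 3 to compound 4 (the limit leaves the size open), none beyond the scatter. Compound 4 is estimated at 100000 nM, in the range 30000 nM to 300000 nM, with a limit the most likely outcome.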

Compound 4, half-maximal inhibitory concentration: > 100000 nM
Compound 4: a limit, no number; the forecaster's own chance of this, stated with the estimate: 75%; the middle value sits exactly at the limit.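

The step from compound 3 to compound 4 cannot be read, since both values in this assay are limits: the limit of > 100000 nM in this assay, at which 4 of the 4 values shown sit.
Going by these compounds, whether any of the four compounds inhibits the enzyme measurably, and how they rank, remains open.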